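Side chain swap on a nearly fully consumed compound

The source may report more compounds than this note shows. Statements on the series, on what has been measured and on what is new or still open speak of the compounds shown alone.

- compound 1 `NC(=O)c1cnc2c(NC3CC3)cc(Nc3cccc(-c4ccc(C(F)(F)F)cc4F)c3)nn12`: 65%
- compound 2 `CNc1cc(Nc2cc(C)cc(C)c2)nn2c(C(=O)NCC(C)(CO)CO)cnc12`: 0%
- compound 3 `CNc1cc(Nc2cc(C)cc(C)c2)nn2c(C(=O)NC3CC3)cnc12`: 1%

These numbers come from an ADME assay on microsomes from liver (Mus musculus) for metabolic stability, read by mass spectrometry, with a stated time of 10 min, tested at 0.5 uM; a lower number here means that less of the compound is left, a higher number that more of the compound is left. Compound 3 gives 1%, which lies within the scatter of compound 2. Far more of compound 1 is left, at 65%, a gap well beyond the scatter. Compound 1 differs from compound 3 in more than one place, however, so this gap says little about a single change.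

The next compound, compound 4 `CNc1cc(Nc2cc(C)cc(C)c2)nn2c(C(=O)NCC(C)(C)CO)cnc12`, keeps the core of compound 3 and alters only the amide side chain: 2-(hydroxymethyl)-2-methylpropyl in place of cyclopropyl on an amide-type nitrogen. In words, 2-(hydroxymethyl)-2-methylpropyl takes the place of cyclopropyl on an amide-type nitrogen.

For the measured compounds named here, one measured step bears on this change, a swap of groups on that same nitrogen: a number 1 percentage points higher from compound 2 to compound 3 (within the scatter). Going by the values given here, it is only a single step, so it offers limited guidance, but it gives no sign that the group at this nitrogen moves the number. The expectation rests on that step and on compound 3 itself, at 1%. No step beyond the scatter is expected in this assay, and the estimate reads no change at the digits printed from compound 3 to compound 4 (within the scatter). For compound 4 the estimated value is 1%, with an expected range of 0% to 8%.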

Compound 4, percent of the compound remaining: 0%
For compound 4 the middle estimate is 1 percentage points above the measured one; the measured number falls inside the stated range.
By their numbers in this assay, from the lowest: compounds 2, 4 and 3 (each within the scatter of the next); then compound 1.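

With compound 4, the amide side chain on this core has now taken three forms. In this assay, putting 2-(hydroxymethyl)-2-methylpropyl in place of cyclopropyl gives a number 1 percentage points lower from compound 3 to compound 4 (within the scatter), and replacing one hydroxy of the side chain with hydrogen gives no change at the digits printed from compound 2 to compound 4 (within the scatter), so neither the ring nor the number of hydroxy groups separates these compounds, although all three sit at the very bottom of the scale, where almost nothing is left and a real difference would be hard to see. Nothing measured here explains why so little of these compounds remains.

On these data alone, whether a different kind of side chain on this nitrogen, such as an amine or a carboxylic acid, would leave more of the compound remains open. Compound 1 gives 65% but differs from the others in more than one place, so the compounds shown cannot say which part of its structure goes with that number, or whether changes away from the amide would matter more.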